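Swapping Benzyl for Chlorothiophene on the Sulfonyl Group

This account rests on a few compounds, and the source may have more. Where it says the series, first, only, none or still open, it means among the compounds named here.

In a functional assay (Platelet, plasma) for inhibition, with Homo sapiens as the target (on this read-out lower numbers stand for stronger inhibition and higher numbers for weaker inhibition), compound 1 `CC1(C(=O)NS(=O)(=O)Cc2ccccc2)CCN(c2nc3c(cc2C#N)C(=O)OC3)CC1` gives 6680 nM and compound 3 `N#Cc1cc2c(nc1N1CCC(C(=O)NS(=O)(=O)Cc3ccc(Cl)cc3)CC1)COC2=O` gives 4420 nM. Compound 2 `CC1OC(=O)c2cc(C#N)c(N3CCC(C(=O)NS(=O)(=O)Cc4ccccc4)CC3)nc21` reaches in this assay only a limit, > 300000 nM. This is the limit of > 300000 nM in this assay, at which 1 of the 3 values shown sits, so compound 2 sits at the weak end of the numbers shown. Compound 4 `CC1OC(=O)c2cc(C#N)c(N3CCC(C(=O)NS(=O)(=O)c4ccc(Cl)s4)CC3)nc21` differs from compound 2 by 5-chlorothiophen-2-yl in place of benzyl on a sulfonyl sulfur. For the measured compounds named here, no measured pair shows what this change does on its own; the step is expected to be modest, toward stronger inhibition or none beyond the scatter. Compound 4 is therefore expected at 150000 nM, between 20000 nM and 1000000 nM. That estimate corresponds to an expected step of an at least 2.0-fold lower number from compound 2 to compound 4 (0.30 log units; that floor lies within the scatter), with a real chance that compound 4 also gives only a limit.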

Compound 4, half-maximal inhibitory concentration: > 300000 nM
Compound 4 was reported as a limit; the forecaster's own chance of this, stated with the estimate: 50%; middle value at least 2.0-fold (0.30 log units) from the limit.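

No step can be read from compound 2 to compound 4, because in this assay both give only a limit: the limit of > 300000 nM in this assay, at which 2 of the 4 values shown sit.

As far as these compounds go, what 5-chlorothiophen-2-yl in place of benzyl on a sulfonyl sulfur does to inhibition remains open.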